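From 4-methylphenyl to 3-methoxyphenyl on the shared core

The compounds below may be only part of what the source reports. "The series", "measured", "known", "first", "only" and "open" are said of these compounds alone.

Of the compounds shown here, three sharing one core have been tested in a functional assay on A549 cells (Homo sapiens) for inhibition, read by MTT assay, with a stated time of 72 h (a lower number here means a stronger inhibitor, a higher number a weaker inhibitor), so far: compound 1 `Cc1cc2occ(-c3nc(-c4ccccc4)c(-c4ccccc4)n3-c3ccc(Cl)c(Cl)c3)c(=O)c2cc1Cl` (6250 nM), compound 2 `Cc1cccc(-n2c(-c3coc4cc(C)c(Cl)cc4c3=O)nc(-c3ccccc3)c2-c2ccccc2)c1` (12500 nM) and compound 3 `Cc1ccc(-n2c(-c3coc4cc(C)c(Cl)cc4c3=O)nc(-c3ccccc3)c2-c2ccccc2)cc1` (12500 nM). Compound 3 sits level with compound 2, and compound 1 lies within the scatter of both.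

The next candidate, compound 4 `COc1cccc(-n2c(-c3coc4cc(C)c(Cl)cc4c3=O)nc(-c3ccccc3)c2-c2ccccc2)c1`, is still unmeasured. It carries 3-methoxyphenyl in place of 4-methylphenyl on an aromatic nitrogen. The core and both phenyl groups stay as they are.

The useful evidence comes from earlier swaps at this same place. Going from one methylphenyl group to the other gave no change at the digits printed from compound 2 to compound 3 (within the scatter) as its result. Replacing 3,4-dichlorophenyl gave a 2.0-fold higher number from compound 1 to compound 2 (0.30 log units; within the scatter) in one case and a 2.0-fold higher number from compound 1 to compound 3 (0.30 log units; within the scatter) in the other. None of these steps goes beyond the scatter. No methoxy group has been tested here, however, so this evidence is indirect and the range must stay wide.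

The expected outcome in this assay is therefore no change at the digits printed from compound 3 to compound 4 (within the scatter) with no real shift in either direction. For compound 4 the estimated value is 12500 nM with an expected range from 6000 nM to 25000 nM in repeat measurements.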

Compound 4, half-maximal inhibitory concentration: 6250 nM
The estimate for compound 4 lay 2.0-fold (0.30 log units) above the measured number; the measured number falls inside the stated range.
By their numbers in this assay, from the lowest: compounds 1, 4, 2 and 3 (each within the scatter of the next).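

In this assay, within the data shown here, the 3-methoxyphenyl group, the only group here that brings a hydrogen-bond acceptor to this aromatic nitrogen, still gives a number within the scatter of all three earlier groups: there is a 2.0-fold lower number from compound 3 to compound 4 (0.30 log units; within the scatter) for the swap from 4-methylphenyl and no change at the digits printed from compound 1 to compound 4 (within the scatter) for the swap from 3,4-dichlorophenyl. The closest comparison is a 2.0-fold lower number from compound 2 to compound 4 (0.30 log units; within the scatter). Only methoxy stands in place of methyl in this step, and it shows that this single change on the aromatic carbon does not carry the number beyond the scatter. The four compounds therefore show that this position tolerates methyl, chloro and methoxy groups on the phenyl ring without a clear shift, although the data offer no explanation for the small steps seen here.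

The compounds shown leave open whether a group of a different kind on this phenyl ring, such as an amine or a carboxylic acid, would produce a step beyond the scatter. They also leave open what a longer chain such as ethoxy or butoxy would do at this place, and how 4-methoxyphenyl would compare with 3-methoxyphenyl.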